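The compounds below may be only part of what the source reports. "The series", "measured", "known", "first", "only" and "open" are said of these compounds alone.

Measured so far:
- compound 1, `O=S(=O)(Nc1nccs1)c1ccc2c(c1)OCC[C@@H]2c1ccc(C(F)(F)F)cc1-c1ccc(F)cn1`: 7000 nM
- compound 2, `O=S(=O)(Nc1ncccn1)c1ccc2c(c1)OCC[C@@H]2c1ccc(C(F)(F)F)cc1-c1ccc(F)nc1`: 408000 nM
- compound 3, `Cn1nccc1-c1cc(C(F)(F)F)ccc1[C@@H]1CCOc2cc(S(=O)(=O)Nc3nccs3)ccc21`: 65000 nM

In a physicochemical assay for solubility (on this read-out lower numbers stand for lower solubility and higher numbers for higher solubility), compound 2 gives the highest of the three numbers. Its nearest neighbour is compound 3, whose value sits well below it, beyond the scatter; compound 1 sits further below still, also beyond the scatter. Within the data shown here, no pair among the three differs in a single place, so no measured step is available as a guide.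

Compound 4, `Cn1nccc1-c1cc(C(F)(F)F)ccc1[C@H]1CCOc2cc(S(=O)(=O)Nc3ncccn3)ccc21`, has not yet been measured. Relative to compound 2 it carries one change: 1-methyl-1H-pyrazol-5-yl in place of 6-fluoropyridin-3-yl on an aromatic carbon. Compound 3 also carries the 1-methyl-1H-pyrazol-5-yl group and gives the middle value of the three, while compound 1 with a fluoropyridinyl group gives the lowest, but those two compounds differ in other places as well, so that comparison is only suggestive.

For compound 4 in this assay a small upward step is expected, at or just beyond the scatter, with a wide range given the absence of any clean matched pair. The expected step from compound 2 to compound 4 is a 1.5-fold higher number from compound 2 to compound 4 (0.17 log units; within the scatter). Compound 4 is estimated at 600000 nM, with a range of 150000 nM to 2500000 nM.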

Compound 4, solubility: 532000 nM
Compound 4: middle estimate off by 1.1-fold (0.05 log units), on the high side; the measured number falls inside the stated range.
By their numbers in this assay, from the lowest: compound 1; then compound 3; then compounds 2 and 4 (each within the scatter of the next).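

Read in this assay the exchange gives a 1.3-fold higher number from compound 2 to compound 4 (0.12 log units; within the scatter) and is the first single-place comparison available in the series. On this aromatic carbon, ortho to a large group and meta to a trifluoromethyl group, the read-out does not separate 6-fluoropyridin-3-yl from 1-methyl-1H-pyrazol-5-yl, although one is a six-membered aromatic ring and the other a five-membered one, so this position tolerates that exchange of aromatic rings without a step beyond the scatter. No measurement shown here speaks to why the two groups read alike.

As far as these compounds go, this rests on one pair, so it remains open whether the same exchange would give a step of similar size with a different ring on the sulfonamide nitrogen, or with other fluoropyridinyl isomers at this carbon. Also open is whether this position stays as undiscriminating for groups of a different kind, such as a primary amine, a carboxylic acid or a morpholine, or for a non-aromatic substituent such as a longer alkyl chain, none of which appear among the compounds shown.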